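The compounds below may be only part of what the source reports. "The series", "measured", "known", "first", "only" and "open" are said of these compounds alone.

Compound 1, `COc1ccc(-c2ccc(-c3ccc(C(=N)N)o3)o2)cc1`: 2220 nM
Compound 2, `COc1cc(OC)cc(-c2ccc(-c3ccc(C(=N)N)o3)o2)c1`: 3510 nM

Of the compounds shown here, two have been measured in a functional assay on OVCAR-4 cells (Homo sapiens) for inhibition, read by sulforhodamine B assay, with a stated time of 48 h; on this read-out lower numbers stand for stronger inhibition of growth and higher numbers for weaker inhibition of growth. Compound 1 gives 2220 nM and compound 2 gives 3510 nM. The two numbers lie within the usual scatter of each other, so neither compound can be called the stronger inhibitor on this evidence; compound 1 simply shows the smaller of the two numbers.

Compound 3, `N=C(N)c1ccc(-c2ccc(-c3ccccc3)o2)o1`, has not yet been measured. It differs from compound 1 in one place: hydrogen in place of methoxy on an aromatic carbon. Going by the values given here, no measured pair shows this exact change, so its effect has to be guessed. Among the compounds with values here, the only guidance comes from compounds 1 and 2, whose values stay within the scatter although they carry a different number of methoxy groups on the same ring, which hints that this part of the molecule is not decisive.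

Compound 3 is therefore expected to land close to compound 1, with a step of about a 1.4-fold higher number from compound 1 to compound 3 (0.13 log units; within the scatter), that is, none beyond the scatter. The estimated value for compound 3 in this assay is 3000 nM, within a range from 1000 nM to 9000 nM.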

Compound 3, concentration for 50% growth inhibition: 3480 nM
Compound 3: middle estimate off by 1.2-fold (0.06 log units), on the low side; the range from low to high includes it.
By their numbers in this assay, from the lowest: compounds 1, 3 and 2 (each within the scatter of the next).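

Replacing the methoxy on the six-membered aromatic ring, para to a large group, with hydrogen gives a 1.6-fold higher number from compound 1 to compound 3 (0.20 log units; within the scatter) in this assay. The earlier compounds shown here only hinted that this part of the molecule might not be decisive, whereas this single change now tests that directly at this position. Compound 3 has no group other than hydrogen at this position and still cannot be told apart from compound 1, so on this read-out the methoxy is not needed for a level of growth inhibition like that of compound 1, and no other kind of measurement is available to explain this result.

From the compounds shown here alone, only methoxy and hydrogen can be compared directly at this position, so it remains open whether an amine, a carboxylic acid, or a longer chain such as butoxy would move the number beyond the usual scatter or leave it unchanged. The compounds shown also all keep the same amidine group on the shared core, so what happens in this assay when that group is replaced by, for example, a simple amine or a nitrile also remains unknown.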